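The compounds below may be only part of what the source reports. "The series", "measured", "known", "first", "only" and "open" are said of these compounds alone.

Compound 1, `C=C(Br)C(=O)Nc1cccc(-c2cn3nc(-c4ccc(C)cc4)sc3n2)c1`, is the strongest inhibitor among the three compounds measured in a functional assay on L1210 cells (Mus musculus) for inhibition, read by cell counting, with a stated time of 2 days (a higher number here means a weaker inhibitor, a lower number a stronger inhibitor), where compound 1 gives 920 nM. The two companions sit well away from it. Compound 2, `Nc1cccc(-c2cn3c(-c4ccc(Cl)cc4)csc3n2)c1`, gives 22000 nM in this assay, and compound 3, `Nc1cccc(-c2cn3nc(Cc4ccc(Cl)cc4)sc3n2)c1`, gives 16000 nM. Both of those numbers lie beyond the scatter from the number for compound 1, but each of these compounds differs from compound 1 in more than one place, so no single step can be read from the pair, and the three measured values offer no direct test of changes on the aryl group that sits on the five-membered ring of the shared core.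

Compound 4, `C=C(Br)C(=O)Nc1cccc(-c2cn3nc(-c4cccc(OC)c4)sc3n2)c1`, remains to be measured in this assay. It differs from compound 1 in exactly one place: 3-methoxyphenyl in place of 4-methylphenyl on an aromatic carbon. Among the measured compounds shown here, nothing among the measured compounds isolates this kind of change, so the expectation rests on the general observation that such a swap tends to move numbers only modestly. The account therefore anticipates an expected 1.4-fold higher number from compound 1 to compound 4 (0.15 log units; within the scatter), small and likely within the scatter, perhaps a slight weakening. Compound 4 is accordingly expected to give about 1300 nM in this assay, with a range from 450 nM to 3800 nM.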

Compound 4, half-maximal inhibitory concentration: 580 nM
Compound 4: the middle estimate sits 2.2-fold (0.35 log units) above what was measured, within the range that was stated.
By their numbers in this assay, from the lowest: compounds 4 and 1 (each within the scatter of the next); then compounds 3 and 2 (each within the scatter of the next).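

In this assay, among the compounds shown here, the exchange of 4-methylphenyl for 3-methoxyphenyl on the aromatic carbon of the five-membered aromatic ring with 2 nitrogen and 1 sulfur gives a 1.6-fold lower number from compound 1 to compound 4 (0.20 log units; within the scatter), and this is the first comparison that isolates a change at this position. Compound 1 and compound 4 therefore cannot be ranked, and the position accepts this particular exchange of one substituted phenyl for another, including the added oxygen, without any change in the number that exceeds the scatter. No independent measurement bears on this result, so the comparison gives no explanation for how the two aryl groups behave here.

This single step changes both the substituent and where it sits on the phenyl ring, so 3-methylphenyl and 4-methoxyphenyl would be needed to separate those two features. The compounds shown also leave open whether a more different group at this position, such as a phenyl ring bearing a carboxylic acid or an amine, or a longer alkyl chain in place of the phenyl ring, would move the number beyond the scatter.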